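A few compounds are considered here, and "the series" means these few. Any claim that something is new, unique, unknown or untested is made for them only; others in the source may bear on it.

Measured so far:
compound 1 `CCCc1nc(-c2ccccc2)c(CNCCCN2CCN(c3ccccc3OC)CC2)o1` — 41%
compound 2 `CCCc1nc(-c2ccccc2)c(CNCCN2CCN(c3ccc(C)cc3)CC2)o1` — 48.1%

In an assay on HEK293 cells for inhibition of Voltage-dependent T-type calcium channel subunit alpha-1G (Homo sapiens), read by fluorescence, tested at 10 uM (on this read-out lower numbers stand for less inhibition and higher numbers for more inhibition at the one concentration tested (going by the name of the read-out)), compound 1 gives 41%, and compound 2 gives 48.1%; the two values lie within the usual scatter of each other, so neither can be called different from the other on this evidence. Compound 3 `CCCc1nc(-c2ccccc2)c(CNCCCN2CCN(c3cccc(Cl)c3)CC2)o1` is not yet measured. It differs from compound 1 by 3-chlorophenyl in place of 2-methoxyphenyl on an amine nitrogen in a ring. Within the data shown here, no measured pair shows what such a change does here, so the step of a number 4 percentage points higher from compound 1 to compound 3 (within the scatter) is expected to stay within the scatter, with no clear direction. Compound 3 is therefore expected to give about 45%, between 25% and 65%.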

Compound 3, a percentage reported as inhibition, at one concentration (the size of the read-out at that concentration, not a potency): 65.9%
For compound 3 the middle estimate is 20.9 percentage points below the measured one; the measured number lies above the stated range.
By their numbers in this assay, from the lowest: compounds 1 and 2 (each within the scatter of the next); then compound 3.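

In this assay, among these compounds, the group on the amine nitrogen in the ring is the first place where a single change moves the number beyond the scatter: 3-chlorophenyl in place of 2-methoxyphenyl brings a number 24.9 percentage points higher from compound 1 to compound 3 (beyond the scatter). The rest of compound 1 stays the same, so this position clearly matters in the series. Nothing available explains the step.

The change alters both the group and where it sits on the phenyl ring, so the two effects cannot be separated. A 2-chlorophenyl or 3-methoxyphenyl group, or plain phenyl, would bear on that question.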